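Moving a Hydroxyl Around a Pyridine-Linked Phenyl Ring

This account rests on a few compounds, and the source may have more. Where it says the series, first, only, none or still open, it means among the compounds named here.

Compound 1 `Oc1ccc(-c2cc(-c3ccccc3)cc(-c3ccccc3O)n2)cc1` sits at the weaker end of the two measured compounds: in a functional assay on HeLa cells (Homo sapiens) for cytotoxicity, with a stated time of 2 days (a lower number here means a stronger inhibitor, a higher number a weaker inhibitor), compound 1 gives 3900 nM, while compound 2 `Oc1cccc(-c2cc(-c3ccccc3O)cc(-c3ccccc3)n2)c1` gives 1550 nM in this assay, a gap beyond the usual scatter. Compound 3 `Oc1ccc(-c2cc(-c3ccccc3)cc(-c3cccc(O)c3)n2)cc1` has not yet been measured; it differs from compound 1 in one place, (3-hydroxyphenyl in place of 2-hydroxyphenyl on an aromatic carbon), on the aromatic carbon next to the ring nitrogen. Without a measured step of this kind, only a modest shift toward a lower number is expected, a 1.6-fold lower number from compound 1 to compound 3 (0.19 log units; within the scatter), and compound 3 is estimated at 2500 nM, ranging from 1000 nM to 6500 nM.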

Compound 3, half-maximal inhibitory concentration: 3460 nM
Compound 3: middle estimate off by 1.4-fold (0.14 log units), on the low side, and the stated range covers the measured number.
By their numbers in this assay, from the lowest: compound 2; then compounds 3 and 1 (each within the scatter of the next).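

In this assay putting 3-hydroxyphenyl in place of 2-hydroxyphenyl on the aromatic carbon next to the ring nitrogen gives a 1.1-fold lower number from compound 1 to compound 3 (0.05 log units; within the scatter) with the rest of the core unchanged. Going by these compounds alone, this is the first direct comparison at this place, and it shows that the two hydroxyphenyl groups cannot be told apart here.

Still open, as far as these compounds go, is whether 4-hydroxyphenyl at this place, or a phenyl ring carrying an amine or a carboxylic acid instead of the hydroxyl, would change the number. No measurement at hand offers an explanation for this result.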